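The source may report more compounds than this note shows. Statements on the series, on what has been measured and on what is new or still open speak of the compounds shown alone.

In a functional assay on aorta (Rattus norvegicus, strain Sprague-Dawley) (on this read-out lower numbers stand for an effect already at smaller amounts and higher numbers for an effect only at larger amounts of compound), the measurements so far are:

Compound 1 `COc1cc(/C=C/C(=O)c2c(O)cc(O)c(CC=C(C)C)c2O)cc(OC)c1OC`, "not determined" (no result reported)
Compound 2 `CC(C)=CCc1c(O)cc(O)c(C(=O)/C=C/c2ccc(Cl)cc2)c1O`, 679000 nM
Compound 3 `CC(C)=CCc1c(O)cc(O)c2c1OC(c1cccc(Br)c1)CC2=O`, 1560 nM

Among the measured compounds shown here, only two of these three compounds have a number. Compound 3, at 1560 nM, holds the lower of the two, so a smaller amount of it is needed for the effect. Compound 2, at 679000 nM, lies far higher, a gap well beyond the usual scatter of repeat measurements. Compound 1 has no result to compare.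

The next compound, compound 4 `COc1cc(C2CC(=O)c3c(O)cc(O)c(CC=C(C)C)c3O2)ccc1O`, keeps the core of compound 3 and changes one group. It carries 4-hydroxy-3-methoxyphenyl in place of 3-bromophenyl on a saturated ring carbon, next to the ring oxygen (4-hydroxy-3-methoxyphenyl in place of 3-bromophenyl on a saturated ring carbon).

For the measured compounds named here, no two measured compounds differ in only one place, so the data give no direct measure of what a single change does in this assay. The starting point is therefore compound 3 at 1560 nM, and the forecast stays cautious. A modest move toward a higher number is expected, with an estimated 3.2-fold higher number from compound 3 to compound 4 (0.51 log units; beyond the scatter), only slightly beyond the scatter. For compound 4 the estimated value is 5000 nM, with an expected range from 700 nM to 35000 nM.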

Compound 4, half-maximal effective concentration: 10100 nM
Estimate against measurement, compound 4: 2.0-fold (0.31 log units) below; measured number inside the range.
By their numbers in this assay, from the lowest: compound 3; then compound 4; then compound 2.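

On the saturated ring carbon next to the ring oxygen, putting 4-hydroxy-3-methoxyphenyl in place of 3-bromophenyl gives a 6.5-fold higher number from compound 3 to compound 4 (0.81 log units; beyond the scatter) in this assay. This is the only single change that can be read among these compounds, and it shows that the number responds to what sits at this position, even though the step is modest and the six-membered aromatic ring of carbon stays in place. What changes is the decoration on that ring: bromine leaves, while the entering group brings oxygen atoms and a hydrogen-bond donor, and no measurement here says what lies behind the rise in the number.

The compounds shown leave open whether the loss of bromine, the gain of the hydroxy group or the gain of the methoxy group accounts for the step, since all three come together in this one change. From the compounds shown here alone, it also remains open how this position would respond to a plain phenyl ring, or to a ring bearing an amine or a carboxylic acid.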